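The compounds below may be only part of what the source reports. "The series", "measured", "known", "first", "only" and "open" are said of these compounds alone.

Among the measured compounds shown here, in a functional assay on HT-29 cells (Homo sapiens) for cytotoxicity, read by MTT assay, with a stated time of 24 h (on this read-out higher numbers stand for weaker inhibition and lower numbers for stronger inhibition), compound 2 `O=Cc1ccccc1OCc1cn(CCCOc2ccc3ccc(=O)oc3c2)nn1` gives 18900 nM, the second highest of the three numbers so far. Compound 3 `CCN(CC)c1ccc(C=O)c(OCc2cn(CCCOc3ccc4ccc(=O)oc4c3)nn2)c1` gives 9030 nM, while compound 1 `C#CCOc1cccc(/C=N/Cc2ccc(S(N)(=O)=O)cc2)c1` gives 104000 nM. The single-change comparison available, a 2.1-fold lower number from compound 2 to compound 3 (0.32 log units; beyond the scatter), came from putting diethylamino in place of hydrogen on an aromatic carbon and was modest. Compound 4 `O=Cc1cc(Br)ccc1OCc1cn(CCCOc2ccc3ccc(=O)oc3c2)nn1` differs from compound 2 by bromo in place of hydrogen on an aromatic carbon of a six-membered aromatic ring of carbon only, meta to a formyl group and para to a large group. For the measured compounds named here, no measured step involves a bromo, so the guidance is weak, and the number is expected to stay close to that of compound 2. Compound 4 is therefore expected to give 15000 nM, between 7000 nM and 40000 nM, which would mean a 1.3-fold lower number from compound 2 to compound 4 (0.10 log units; within the scatter).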

Compound 4, half-maximal inhibitory concentration: 7470 nM
For compound 4 the middle estimate is 2.0-fold (0.30 log units) above the measured one; low and high end bracket the measured number.
By their numbers in this assay, from the lowest: compounds 4 and 3 (each within the scatter of the next); then compound 2; then compound 1.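

In this assay, a 2.5-fold lower number from compound 2 to compound 4 (0.40 log units; beyond the scatter) shows that one bromine atom, para to a large group and meta to a formyl group, is enough to move the number beyond the scatter. Together with a 2.1-fold lower number from compound 2 to compound 3 (0.32 log units; beyond the scatter) on the same ring, it makes two changes to this ring that lower the number from compound 2, though each step is modest. From the compounds shown here alone, whether chloro or methoxy in the same place would lower the number as well stays open. Nothing measured here explains the step from bromo.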